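This account rests on a few compounds, and the source may have more. Where it says the series, first, only, none or still open, it means among the compounds named here.

Among the compounds with values here, in a functional assay on the whole organism for inhibition, with Rattus norvegicus as the target, read by cytopathic effect and paw edema, at a dose of 100 mg/kg by the oral route (a lower number here means less inhibition, a higher number more inhibition at the dose given (going by the name of the read-out)), compound 2 `O=C(Nc1cccnc1)c1c(O)c2cccnc2n(-c2ccccc2)c1=O` stands highest of the two numbers measured so far, giving 30.8%. Within the data shown here, compound 1 `COc1cccc(NC(=O)c2c(O)c3cccnc3n(-c3ccccc3)c2=O)c1` gives 20.7% in the same assay, and the only step measured between these two compounds is a number 10.1 percentage points higher from compound 1 to compound 2 (beyond the scatter). Compound 3 `O=C(NCc1ccncc1)c1c(O)c2cccnc2n(-c2ccccc2)c1=O` is not yet measured; it differs from compound 2 by (pyridin-4-yl)methyl in place of pyridin-3-yl on an amide-type nitrogen. Among the measured compounds shown here, none of the measured steps bears on this particular change: the single step known concerns pyridin-3-yl in place of 3-methoxyphenyl, not the insertion of a methylene between the ring and the amide-type nitrogen, so there is no direct precedent for the direction or size of the effect. For the measured compounds named here, with only one modest step to draw on, the change is expected to leave the number about where compound 2 stands, with a step of a number 2.8 percentage points lower from compound 2 to compound 3 (within the scatter) that would not exceed the scatter. Compound 3 is therefore estimated to give 28%, in a range from 12% to 45%.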

Compound 3, a percentage reported as inhibition, in the whole organism at one dose (the size of the read-out at that dose, not a potency): 15.4%
Compound 3: the middle estimate sits 12.6 percentage points above what was measured; the range from low to high includes it.
By their numbers in this assay, from the lowest: compounds 3 and 1 (each within the scatter of the next); then compound 2.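

In this assay the amide-type nitrogen proves sensitive to more than the earlier swap: (pyridin-4-yl)methyl in place of pyridin-3-yl brings a number 15.4 percentage points lower from compound 2 to compound 3 (beyond the scatter) and gives up the gain held by compound 2. Set against 3-methoxyphenyl, the same group brings a number 5.3 percentage points lower from compound 1 to compound 3 (within the scatter) at this position, so a group with one six-membered aromatic ring with 1 hetero atom does not by that alone hold the higher number. Nothing measured here accounts for these steps.

The compounds shown leave open whether the methylene or the place of the ring nitrogen goes with the lower number, since both differ at once from compound 2 to compound 3. A pyridin-4-yl group set directly on the amide-type nitrogen, or a (pyridin-3-yl)methyl group, would separate the two.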